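A few compounds are considered here, and "the series" means these few. Any claim that something is new, unique, unknown or untested is made for them only; others in the source may bear on it.

Working notes on the series.

The series was run in an assay on isolated protein for inhibition of protein deacetylase HDAC6 (Homo sapiens), read by fluorescence; on this read-out higher numbers stand for weaker inhibition and lower numbers for stronger inhibition. Compound 1 `Cn1cc(-c2ccccc2Oc2ccccc2)c2cc(C(=O)NCCCCCCC(=O)NO)[nH]c2c1=O` gives 4.7 nM in this assay. Compound 3 `CC(C)Oc1ccc(C(C)(C)O)cc1-c1cn(C)c(=O)c2[nH]c(C(=O)NCCCCCCC(=O)NO)cc12` gives 5.4 nM, a number that sits within the scatter of the value for compound 1. Compound 2 `Cc1cc(F)cc(C)c1Oc1ccc(C(C)(C)O)cc1-c1cn(C)c(=O)c2[nH]c(C(=O)NCc3ccc(C(=O)NO)cc3)cc12` gives 39.3 nM, a weaker value that lies beyond the scatter of compound 1. Compound 1 therefore holds the lowest of the three numbers, but it cannot be set apart from compound 3.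

Compound 4 `Cn1cc(-c2ccccc2Oc2ccccc2)c2cc(C(=O)NCCCC(=O)NO)[nH]c2c1=O` has not yet been measured in this assay. Against compound 1 it carries one change: hydroxycarbamoyl in place of 3-(hydroxycarbamoyl)propyl on a saturated chain carbon, three bonds along the chain from an amide-type nitrogen. The hydroxamic acid is kept, but the chain that carries it from the amide-type nitrogen is shorter. Among the measured compounds shown here, no measured pair shows a step of this kind, so the size of the step is an open estimate.

The expectation is a weaker number for compound 4, with a step from compound 1 to compound 4 of a 17-fold higher number from compound 1 to compound 4 (1.23 log units; beyond the scatter), beyond the scatter. Compound 4 is estimated at 80 nM in this assay, within a range from 20 nM to 400 nM.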

Compound 4, half-maximal inhibitory concentration: 144 nM
Beside the measured number, compound 4's estimate is 1.8-fold (0.26 log units) below it; the measured number falls inside the stated range.
By their numbers in this assay, from the lowest: compounds 1 and 3 (each within the scatter of the next); then compound 2; then compound 4.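

Among the compounds shown here, the change from 6-(hydroxycarbamoyl)hexyl to 3-(hydroxycarbamoyl)propyl gives the first one-place step, a 31-fold higher number from compound 1 to compound 4 (1.49 log units; beyond the scatter) in this assay, and this step is large. The hydroxamic acid and the rest of compound 1 are kept, so at this position the length of the chain alone moves the number well beyond the scatter. The compounds shown give no data that account for the size of this step.

Open, on these data alone, is how the number moves with a chain of intermediate length or a longer chain than 6-(hydroxycarbamoyl)hexyl, since two lengths do not fix the shape of the trend. Also open, as far as these compounds go, are whether the same shortening gives a step of similar size on the core of compound 3, and what a carboxylic acid does in place of the hydroxamic acid.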